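The source may report more compounds than this note shows. Statements on the series, on what has been measured and on what is new or still open speak of the compounds shown alone.

Three compounds share one core and differ only in the group attached to a carbonyl carbon: compound 1 `O=C(NC(=S)N1CCc2c(OCCCCCOc3ccc(Cl)cc3)cccc21)c1cccc([N+](=O)[O-])c1`, compound 2 `O=C(NC(=S)N1CCc2c(OCCCCCOc3ccc(Cl)cc3)cccc21)c1ccc(C(F)(F)F)cc1` and compound 3 `O=C(NC(=S)N1CCc2c(OCCCCCOc3ccc(Cl)cc3)cccc21)c1ccoc1`. In an ADME assay on Huh-7 cells (Homo sapiens) for cytotoxicity (on this read-out higher numbers stand for lower toxicity in this test and lower numbers for higher toxicity in this test), compound 1 gives 12100 nM, compound 2 gives 32700 nM and compound 3 gives 20100 nM. Going by the values given here, compound 3 holds the second highest of these three numbers; the steps of a 1.6-fold lower number from compound 2 to compound 3 (0.21 log units; within the scatter) and a 1.7-fold higher number from compound 1 to compound 3 (0.22 log units; within the scatter) both stay within the scatter, and only the step of a 2.7-fold higher number from compound 1 to compound 2 (0.43 log units; beyond the scatter) reaches beyond it. Compound 4 `S=C(NC(=S)N1CCc2c(OCCCCCOc3ccc(Cl)cc3)cccc21)Oc1ccccc1` brings a different kind of change: a group of 9 heavy atoms (7 carbon, 1 oxygen, 1 sulfur; one six-membered aromatic ring of carbon only) in place of a group of 7 heavy atoms (5 carbon, 2 oxygen; one five-membered aromatic ring with 1 hetero atom), on an amide-type nitrogen. Among the compounds with values here, none of the measured steps touches this part of the molecule, so no step beyond the scatter is expected. The step of a 1.0-fold lower number from compound 3 to compound 4 (0.00 log units; within the scatter) is the expected outcome. Compound 4 is estimated at 20000 nM, within 7000 nM to 60000 nM.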

Compound 4, half-maximal cytotoxic concentration: > 50000 nM
Compound 4: a limit, no number; the forecaster's own chance of this, stated with the estimate: 10%; middle value at least 2.5-fold (0.39 log units) from the limit.
By their numbers in this assay, from the lowest: compounds 1, 3 and 2 (each within the scatter of the next, the first and the last beyond it). At a limit, above all of these: compound 4.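

In this assay compound 4 reads as a limit of the assay, not a number: the limit of > 50000 nM in this assay, at which 1 of the 4 values shown sits.

Compounds 1, 2 and 3 all kept a carbonyl on this amide-type nitrogen, whereas the group that enters here carries sulfur and a six-membered aromatic ring of carbon only. This change gives an at least 2.4-fold higher number from compound 3 to compound 4 (0.39 log units; beyond the scatter) and an at least 4.1-fold higher number from compound 1 to compound 4 (0.61 log units; beyond the scatter), but an at least 1.5-fold higher number from compound 2 to compound 4 (0.18 log units; that floor lies within the scatter) leaves that pair unseparated.

The compounds shown leave open whether the sulfur or the rest of the new group accounts for these steps. They also leave open whether an amine or a carboxylic acid on its ring would preserve them.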